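The source may hold more compounds than are shown below. What is called first, only, known or untested is meant among the compounds shown, and "the series" means these compounds.

Measured in a functional assay on A549 cells (Homo sapiens) for cytotoxicity, read by MTT assay, with a stated time of 72 h; on this read-out lower numbers stand for stronger inhibition and higher numbers for weaker inhibition:
compound 1 `CN(C)CCCCCn1c2c(c3ccccc31)C(=O)c1c[n+]([O-])c3ccccc3c1C2=O`: 210 nM
compound 2 `CN1CCN(CCCn2c3c(c4ccccc42)C(=O)c2c[n+]([O-])c4ccccc4c2C3=O)CC1`: 140 nM
compound 3 `O=C1c2c[n+]([O-])c3ccccc3c2C(=O)c2c1c1ccccc1n2Cc1cn(C[C@@H](O)CO)nn1`: 390 nM

Compound 3 carries the highest number of the three, but only one of its gaps is beyond the scatter. The data show a 2.8-fold higher number from compound 2 to compound 3 (0.44 log units; beyond the scatter), while the other gap is a 1.9-fold higher number from compound 1 to compound 3 (0.27 log units; within the scatter).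

The next step leads to compound 4 `O=C1c2c[n+]([O-])c3ccccc3c2C(=O)c2[nH]c3ccccc3c21`: hydrogen in place of (1-(2,3-dihydroxypropyl)-1H-1,2,3-triazol-4-yl)methyl on an aromatic nitrogen. Among the measured compounds shown here, no measured step removes the side chain. Each one only exchanges one chain for another, so they bear on this change indirectly. Besides the two steps above, the third is a 1.5-fold lower number from compound 1 to compound 2 (0.18 log units; within the scatter). The largest of the three is therefore modest, and none shows what a bare nitrogen does. No direction can be read from these steps, so in this assay no step beyond the scatter is expected, though the uncertainty is wide.

The expected change is a 1.3-fold lower number from compound 3 to compound 4 (0.11 log units; within the scatter). The value estimated for compound 4 is 300 nM, with an expected range from 80 nM to 1100 nM.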

Compound 4, half-maximal inhibitory concentration: 320 nM
Compound 4: the middle estimate sits 1.1-fold (0.03 log units) below what was measured; the measured number falls inside the stated range.
By their numbers in this assay, from the lowest: compounds 2, 1, 4 and 3 (each within the scatter of the next, the first and the last beyond it).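

In this assay, the hydrogen of compound 4 on the aromatic nitrogen does about as well as the large side chain it replaces (a 1.2-fold lower number from compound 3 to compound 4 (0.09 log units; within the scatter)), so losing the (1-(2,3-dihydroxypropyl)-1H-1,2,3-triazol-4-yl)methyl group and its 11 heavy atoms gives no change beyond the scatter. The same holds against the 5-(dimethylamino)pentyl chain (a 1.5-fold higher number from compound 1 to compound 4 (0.18 log units; within the scatter)), while only the 3-(4-methylpiperazin-1-yl)propyl chain stands apart from hydrogen, by a modest step (a 2.3-fold higher number from compound 2 to compound 4 (0.36 log units; beyond the scatter)), making compound 2 the one exception to a side chain that otherwise leaves the number unmoved. No measurement on hand accounts for these steps.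

Open, going by these compounds, is whether a small methyl group on this nitrogen behaves like hydrogen. Also open, on these data alone, is whether a morpholine or a carboxylic acid at the end of a propyl chain keeps the step seen with the 4-methylpiperazine.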